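Swapping a Methoxyphenyl Group for a Hydroxyphenyl Group

This account rests on a few compounds, and the source may have more. Where it says the series, first, only, none or still open, it means among the compounds named here.

Among the compounds with values here, in a functional assay on 1A9 cells (Homo sapiens) for cytotoxicity (a lower number here means that less compound is needed, a higher number that more compound is needed for the effect), compound 1 `COC1=C(C)C(=O)/C(=C(O)/C=C/c2ccc(OC)cc2)C(=O)C1(C)C` gives 2.8 ug/mL and compound 2 `COC1=C(C)C(=O)/C(=C(O)/C=C/c2ccccc2OC)C(=O)C1(C)C` gives 2.5 ug/mL, so compound 2 stands within the scatter of the only other number available. Compound 3 `COC1=C(C)C(=O)/C(=C(O)/C=C/c2ccc(O)cc2)C(=O)C1(C)C` brings a new group: 4-hydroxyphenyl in place of 2-methoxyphenyl on a double-bonded chain carbon bound to a double-bonded chain carbon. Within the data shown here, the one measured step, a 1.1-fold lower number from compound 1 to compound 2 (0.05 log units; within the scatter), only exchanged 4-methoxyphenyl for 2-methoxyphenyl, and no measured compound carries 4-hydroxyphenyl, so the guidance is thin. Resting on that small step, this assay is expected to show a 1.1-fold higher number from compound 2 to compound 3 (0.03 log units; within the scatter) with nothing beyond the scatter. Compound 3 is estimated at 2.7 ug/mL with a range from 1.1 ug/mL to 6.5 ug/mL.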

Compound 3, concentration for half-maximal effect: 2.9 ug/mL
Compound 3: the middle estimate sits 1.1-fold (0.03 log units) below what was measured, within the range that was stated.
By their numbers in this assay, from the lowest: compounds 2, 1 and 3 (each within the scatter of the next).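

Within the data shown here, with 4-hydroxyphenyl, this position carries a hydrogen-bond donor for the first time, yet this assay separates it from neither methoxyphenyl compound. Hydrogen in place of methyl on an oxygen on an aromatic ring gives (a 1.0-fold higher number from compound 1 to compound 3 (0.02 log units; within the scatter)), and 4-hydroxyphenyl in place of 2-methoxyphenyl gives (a 1.2-fold higher number from compound 2 to compound 3 (0.06 log units; within the scatter)). So at this position, the oxygen-bearing aromatic groups shown can be exchanged without a step beyond the scatter. On these data alone, whether an amine or a carboxylic acid on this aromatic ring would also stay within the scatter remains open. No supporting evidence on these compounds is available to explain the result.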